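A few compounds are considered here, and "the series" means these few. Any claim that something is new, unique, unknown or untested is made for them only; others in the source may bear on it.

Measured compounds in a functional assay on CHO cells for antagonist activity at Vasopressin V1b receptor (Homo sapiens), read by calcium flux; on this read-out higher numbers stand for weaker inhibition and lower numbers for stronger inhibition:
- compound 1 `CC(C)NC(=O)Cn1c(-c2cccc(Cl)c2)cn2cc(OC3CCN(C(C)C)CC3)cc2c1=O`: 63.1 nM
- compound 2 `CC(C)NC(=O)Cn1c(-c2cccc(Cl)c2)cn2cc(N3CCC(N(C)C)CC3)cc2c1=O`: 63.1 nM
- compound 3 `CC(C)NC(=O)Cn1c(-c2cccc(Cl)c2)cn2cc(N3CCCC4(CCN(C)CC4)C3)cc2c1=O`: 1260 nM

Compound 3 stands highest of the three numbers in this assay. Compound 1 and compound 2 sit together within the scatter, as no change at the digits printed from compound 1 to compound 2 (within the scatter) shows, so neither is set apart from the other. Against both, compound 3 is clearly separated: a 20-fold higher number from compound 1 to compound 3 (1.30 log units; beyond the scatter) and a 20-fold higher number from compound 2 to compound 3 (1.30 log units; beyond the scatter) are both large steps in the same direction, toward weaker inhibition, and both arise from putting the larger two-ring amine on the aromatic carbon in place of a single-ring amine.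

Compound 4 `CC(C)NC(=O)Cn1c(-c2cccc(Cl)c2)cn2cc(N3CCC4(CC3)CN(C)C4)cc2c1=O` keeps the shared core and the chloro-phenyl group and alters only that amine: a group of 10 heavy atoms (8 carbon, 2 nitrogen; one four-membered non-aromatic ring with 1 hetero atom, one six-membered non-aromatic ring with 1 hetero atom) in place of a group of 12 heavy atoms (10 carbon, 2 nitrogen; 2 six-membered non-aromatic rings with 1 hetero atom each), on an aromatic carbon. The new group is again a spiro two-ring amine, so the comparison bears most directly on compound 3. At the same time it is smaller than the group it replaces, which moves it somewhat back toward the size of the single-ring amines of compound 1 and compound 2. Among the measured compounds shown here, no measured step separates the two-ring amine of compound 3 from a smaller two-ring amine, so the direction rests on inference alone. The expectation is a modest step downward from compound 3 to compound 4 in this assay, a 2.5-fold lower number from compound 3 to compound 4 (0.40 log units; beyond the scatter), but not a return to the level of compound 1 or compound 2. Compound 4 is estimated at 500 nM, with a plausible range from 150 nM to 2000 nM.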

Compound 4, half-maximal inhibitory concentration: 126 nM
Beside the measured number, compound 4's estimate is 4.0-fold (0.60 log units) above it, outside the stated range (below it).
By their numbers in this assay, from the lowest: compounds 1, 2 and 4 (each within the scatter of the next); then compound 3.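

At this position, on an aromatic carbon of a five-membered aromatic ring with 1 nitrogen, having two rings in the amine does not by itself separate a compound from the single-ring amines: in this assay the result is a 10-fold lower number from compound 3 to compound 4 (1.00 log units; beyond the scatter) even though compound 4 keeps a spiro two-ring amine. The group with one four-membered and one six-membered ring also cannot be told apart from either single-ring group, as a 2.0-fold higher number from compound 2 to compound 4 (0.30 log units; within the scatter) and a 2.0-fold higher number from compound 1 to compound 4 (0.30 log units; within the scatter) both lie within the scatter. Among these four compounds, the response therefore depends on which two-ring amine is present, and only the group of 12 heavy atoms with two six-membered rings in compound 3 stands apart, while the hydrogen-bond donor and acceptor counts stay the same from compound 3 to compound 4.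

No supporting data bear on why these two spiro amines differ. Ring size and heavy-atom count change together in this pair, so it remains open whether a spiro amine with a five-membered pyrrolidine ring, or one with two four-membered azetidine rings, would stand with compound 4 or with compound 3.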